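Bisbrominated shared-core series: heptyl replacing dimethoxyphenyl

This account rests on a few compounds, and the source may have more. Where it says the series, first, only, none or still open, it means among the compounds named here.

Within the data shown here, compound 2 `COc1ccc(C(c2c[nH]c3ccc(Br)cc23)c2c[nH]c3ccc(Br)cc23)c(OC)c1` carries a 2,4-dimethoxyphenyl group on the saturated chain carbon bound to two aromatic carbons; in a functional assay on HeLa cells (Homo sapiens) for inhibition, read by MTT assay, with a stated time of 48 h (on this read-out higher numbers stand for weaker inhibition and lower numbers for stronger inhibition), compound 2 gives 63200 nM, the highest of the two numbers known so far. Among the measured compounds shown here, its nearest neighbour is compound 1 `COc1ccc(C(c2c[nH]c3ccc(Br)cc23)c2c[nH]c3ccc(Br)cc23)cc1`, which in this assay gives 5500 nM; the step of an 11-fold higher number from compound 1 to compound 2 (1.06 log units; beyond the scatter) is the only measured step in the set. Compound 3 `CCCCCCCC(c1c[nH]c2ccc(Br)cc12)c1c[nH]c2ccc(Br)cc12` is not yet measured. It differs from compound 2 as follows: heptyl in place of 2,4-dimethoxyphenyl on a saturated chain carbon bound to two aromatic carbons. For the measured compounds named here, no measured step covers an exchange of an aromatic group for a chain at this carbon; the step from compound 1 to compound 2 only shows that adding a methoxy group to the ring raised the number markedly, so taking the whole dimethoxyphenyl group away may at least undo that part. The direction is therefore taken as a lower number, the size uncertain and the range wide. Compound 3 is expected to give about 10000 nM in this assay, with a range of 2000 nM to 60000 nM, an estimated step of a 6.3-fold lower number from compound 2 to compound 3 (0.80 log units; beyond the scatter).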

Compound 3, half-maximal inhibitory concentration: 1300 nM
Beside the measured number, compound 3's estimate is 7.7-fold (0.89 log units) above it; the measured number lies below the stated range.
By their numbers in this assay, from the lowest: compound 3; then compound 1; then compound 2.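

In this assay, the saturated chain carbon bound to two aromatic carbons does not need an aromatic ring to give a low number: heptyl in place of 2,4-dimethoxyphenyl gives the largest step in the set (a 49-fold lower number from compound 2 to compound 3 (1.69 log units; beyond the scatter)), and heptyl in place of 4-methoxyphenyl also lowers the number (a 4.2-fold lower number from compound 1 to compound 3 (0.63 log units; beyond the scatter)). Among these compounds, until now the only step concerned a methoxy group on the ring, whereas these two steps show that the group as a whole can be exchanged for a chain. Since the heptyl compound 3 falls below compound 1 as well as compound 2, the exchange does more than undo the rise that came with the added methoxy group, and compound 3 is the strongest of the three on this read-out.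

Still open, on these data alone, is whether this depends on heptyl itself, for instance whether a pentyl or nonyl chain, a chain ending in an amine or a carboxylic acid, or a plain phenyl ring at this carbon would give a similar number. The data at hand offer no explanation for any of these steps.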